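The compounds below may be only part of what the source reports. "The series", "measured", "known", "first", "only" and "open" are said of these compounds alone.

Compound 1 `Cc1ccc(S(=O)(=O)N2C/C(=C\c3cccnc3)C(=O)/C(=C/c3ccccc3F)C2)cc1`: 4200 nM
Compound 2 `O=C1/C(=C/c2cccnc2)CN(S(=O)(=O)c2ccc(F)cc2)C/C1=C\c1ccccc1F`: 15600 nM

In a functional assay on HepG2 cells (Homo sapiens) for cytotoxicity, read by MTT assay, with a stated time of 24 h (on this read-out higher numbers stand for weaker inhibition and lower numbers for stronger inhibition), compound 1 gives 4200 nM, the lowest of the two numbers shown. The nearest measured compound is compound 2, which gives 15600 nM. Within the data shown here, the single measured step, a 3.7-fold higher number from compound 1 to compound 2 (0.57 log units; beyond the scatter), concerns fluoro in place of methyl on an aromatic carbon.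

Compound 3 `Cc1ccc(S(=O)(=O)N2C/C(=C\c3ccncc3)C(=O)/C(=C/c3ccccc3F)C2)cc1` has not yet been measured in this assay. It differs from compound 1 by pyridin-4-yl in place of pyridin-3-yl on a double-bonded chain carbon bound to a double-bonded ring carbon. Among the measured compounds shown here, no measured step bears on this change: the step from compound 1 to compound 2 alters the sulfonyl aryl group and says nothing about exchanging pyridin-3-yl for pyridin-4-yl. With no evidence pointing in either direction, compound 3 is expected to show no step beyond the scatter, the estimated step being no change at the digits printed from compound 1 to compound 3 (within the scatter). Compound 3 is therefore estimated at 4200 nM, within a range from 1400 nM to 12600 nM.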

Compound 3, half-maximal inhibitory concentration: 9700 nM
Compound 3: the middle estimate sits 2.3-fold (0.36 log units) below what was measured; the measured number falls inside the stated range.
By their numbers in this assay, from the lowest: compound 1; then compounds 3 and 2 (each within the scatter of the next).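

In this assay, pyridin-4-yl in place of pyridin-3-yl on a double-bonded chain carbon bound to a double-bonded ring carbon gives a 2.3-fold higher number from compound 1 to compound 3 (0.36 log units; beyond the scatter). This shows that the number responds to this position as well as to the sulfonyl aryl group, where the earlier step was a 3.7-fold higher number from compound 1 to compound 2 (0.57 log units; beyond the scatter), and that it does so even though the two pyridinyl groups have the same atoms and the same counts of donors and acceptors. No data shown here account for the step.

The compounds shown leave open whether pyridin-2-yl or a plain phenyl at this position would give a number closer to that of compound 1 or further from it. From the compounds shown here alone, it is also open whether the pyridin-4-yl step would hold with fluoro in place of methyl on the sulfonyl aryl group.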